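The source may hold more compounds than are shown below. What is called first, only, known or untested is meant among the compounds shown, and "the series" means these compounds.

In a functional assay on MT4 cells (Homo sapiens) for cytotoxicity (a lower number here means a stronger inhibitor, a higher number a weaker inhibitor), compound 1 `CN(C)CCNc1nc2c(c(=N)n1-c1ccccc1)c(=S)n(-c1ccccc1)c(=S)n2-c1ccccc1` gives 8400 nM. Among the measured compounds shown here, compound 2 `CN(C)CCCNc1nc2c(c(=N)n1-c1ccccc1)c(=S)n(-c1ccccc1)c(=S)n2-c1ccccc1` gives 1700 nM, the lower of the two numbers measured so far. Compound 3 `CN1CCN(c2nc3c(c(=N)n2-c2ccccc2)c(=S)n(-c2ccccc2)c(=S)n3-c2ccccc2)CC1` is the next to be tested, and its change from compound 2 is 4-methylpiperazin-1-yl in place of (3-(dimethylamino)propyl)amino on an aromatic carbon. For the measured compounds named here, only one measured step is available as a guide, and it bears on this change only indirectly. That step, a 4.9-fold lower number from compound 1 to compound 2 (0.69 log units; beyond the scatter), altered the saturated chain and introduced no ring. Going by the values given here, no measured compound shows what replacing the open chain with a ring does. A modest move toward a higher number is therefore expected, of about the same size as that one step. The expected step is a 2.4-fold higher number from compound 2 to compound 3 (0.37 log units; beyond the scatter). For compound 3 the estimated value is 4000 nM, with an expected range from 1200 nM to 14000 nM.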

Compound 3, half-maximal inhibitory concentration: > 100000 nM
Compound 3 ended at the assay's limit; the forecaster's own chance of this, stated with the estimate: 10%; middle value at least 25-fold (1.39 log units) away from the limit.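

In this assay compound 3 gives > 100000 nM, which is a limit of the assay and not a number: the limit of > 100000 nM in this assay, at which 1 of the 3 values shown sits. The earlier compounds shown here showed only a change in the length of the open chain on this aromatic carbon between two ring nitrogen atoms, whereas the swap to 4-methylpiperazin-1-yl gives an at least 58-fold higher number from compound 2 to compound 3 (1.76 log units; beyond the scatter) and an at least 11-fold higher number from compound 1 to compound 3 (1.07 log units; beyond the scatter). This swap keeps the 7 heavy atoms of the (3-(dimethylamino)propyl)amino group but adds a ring and loses the hydrogen-bond donor, and it moves the number much further than a 4.9-fold lower number from compound 1 to compound 2 (0.69 log units; beyond the scatter) did. The compounds shown do not separate the gain of the ring from the loss of the donor. Going by these compounds, how a longer dimethylamino chain or a morpholine ring at this carbon would read also stays open.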